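Bromo to Nitrile on the Outer Ring: Expected Cytotoxicity

This account rests on a few compounds, and the source may have more. Where it says the series, first, only, none or still open, it means among the compounds named here.

Compound 1 `COc1ccc(-c2ccc(C(O)Cc3cc(OC)c(OC)cc3[N+](=O)[O-])cc2)cc1`: in an ADME assay on HeLa Rh cells (Homo sapiens) for cytotoxicity, read by microscopy (a lower number here means that less compound is tolerated, a higher number that more compound is tolerated), compound 1 reaches only a limit of the assay, > 244000 nM.
Compound 2 `COc1cc(CC(O)c2ccc(-c3ccc(Br)cc3)cc2)c([N+](=O)[O-])cc1OC`: in this assay compound 2 gives 4300 nM.

For the measured compounds named here, compound 2 holds the only measured number. Compound 1 sits at the limit of > 244000 nM in this assay, at which 1 of the 2 values shown sits. Going by the values given here, the single measured step, an at least 56-fold lower number from compound 1 to compound 2 (1.75 log units; beyond the scatter), shows that the group on the outer ring can move the read-out a great deal. Compound 3 `COc1cc(CC(O)c2ccc(-c3ccccc3C#N)cc2)c([N+](=O)[O-])cc1OC` differs from compound 2 by 2-cyanophenyl in place of 4-bromophenyl on an aromatic carbon. Among the compounds with values here, no measured step covers a nitrile, so the expectation rests only on that one large shift, and the direction is uncertain. Compound 3 is estimated at 30000 nM, between 5000 nM and 244000 nM, which means an expected step of a 7.0-fold higher number from compound 2 to compound 3 (0.84 log units; beyond the scatter) that may reach beyond the scatter.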

Compound 3, half-maximal cytotoxic concentration: 9300 nM
For compound 3 the middle estimate is 3.2-fold (0.51 log units) above the measured one; the measured number falls inside the stated range.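

In this assay, replacing 4-bromophenyl with 2-cyanophenyl gives a 2.2-fold higher number from compound 2 to compound 3 (0.34 log units; beyond the scatter), a modest change beside the large gap that separates the methoxy compound from both others. That gap holds for the nitrile too, with an at least 26-fold lower number from compound 1 to compound 3 (1.41 log units; beyond the scatter). Compound 1 remains a limit of the assay, not a number: the limit of > 244000 nM in this assay, at which 1 of the 3 values shown sits.

This swap changes both the group and its place on the ring, so the two cannot be told apart. As far as these compounds go, how an amine or a carboxylic acid on the outer ring would read remains open.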